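Ester variation on the shared core against gastric carcinoma cells

A few compounds are considered here, and "the series" means these few. Any claim that something is new, unique, unknown or untested is made for them only; others in the source may bear on it.

Measured compounds in a functional assay on MGC-803 cells (Homo sapiens) for cytotoxicity, read by MTT assay, with a stated time of 72 h; on this read-out higher numbers stand for weaker inhibition and lower numbers for stronger inhibition:
compound 1, `C=C1C(=O)[C@@]23C(=O)OC[C@]4(C(=O)CCC(C)(C)[C@H]4C=O)[C@@H]2CC[C@@H]1[C@H]3OC(C)=O`: 1660 nM
compound 2, `C=C1C(=O)[C@@]23C(=O)OC[C@]4(C(=O)CCC(C)(C)[C@H]4C=O)[C@@H]2CC[C@@H]1[C@H]3OC(=O)CC`: 1780 nM
compound 3, `C=C1C(=O)[C@@]23C(=O)OC[C@]4(C(=O)CCC(C)(C)[C@H]4C=O)[C@@H]2CC[C@@H]1[C@H]3OC(=O)c1ccccc1F`: 3940 nM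

Compound 2 gives the second highest of the three numbers in this assay. Its nearest neighbour is compound 1, the two separated only by a 1.1-fold higher number from compound 1 to compound 2 (0.03 log units; within the scatter); its furthest is compound 3, reached by a 2.2-fold higher number from compound 2 to compound 3 (0.35 log units; beyond the scatter). Among the measured compounds shown here, the only change in this set that goes beyond the scatter is therefore the replacement of a small alkyl on the carbonyl carbon by an aryl: a 2.4-fold higher number from compound 1 to compound 3 (0.38 log units; beyond the scatter) and a 2.2-fold higher number from compound 2 to compound 3 (0.35 log units; beyond the scatter) both point to weaker inhibition by a modest margin.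

Compound 4, `C=C1C(=O)[C@@]23C(=O)OC[C@]4(C(=O)CCC(C)(C)[C@H]4C=O)[C@@H]2CC[C@@H]1[C@H]3OC(=O)c1ccccc1Cl`, follows the same line from compound 2: 2-chlorophenyl in place of ethyl on a carbonyl carbon. Both aryl steps bear on it, since in each case a one- or two-carbon chain on the carbonyl carbon gave way to a halogen-bearing phenyl, and both moved the number upward by a modest, similar amount. A step of the same kind is expected here, toward weaker inhibition, estimated as a 2.2-fold higher number from compound 2 to compound 4 (0.35 log units; beyond the scatter). Compound 4 is thus expected to give about 4000 nM in this assay, with a range of 2000 nM to 9000 nM; only compound 3 offers a direct precedent, so the range is kept wide.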

Compound 4, half-maximal inhibitory concentration: 2660 nM
Beside the measured number, compound 4's estimate is 1.5-fold (0.18 log units) above it; the measured number falls inside the stated range.
By their numbers in this assay, from the lowest: compounds 1, 2, 4 and 3 (each within the scatter of the next, the first and the last beyond it).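

In this assay, swapping the alkyl group on this carbonyl carbon for 2-chlorophenyl stays within the scatter, whether the group replaced is ethyl (a 1.5-fold higher number from compound 2 to compound 4 (0.17 log units; within the scatter)) or methyl (a 1.6-fold higher number from compound 1 to compound 4 (0.20 log units; within the scatter)). An aryl group at this place therefore does not in itself carry the number beyond the scatter, which the fluorinated compound 3 alone had suggested. The halogen exchange on the ring is also within the scatter (a 1.5-fold lower number from compound 3 to compound 4 (0.17 log units; within the scatter)), so compound 4 cannot be told apart from any of the other three, and the two steps beyond the scatter both rest on compound 3 alone. No supporting data accompany these numbers that could account for them.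

Still open, as far as these compounds go, is whether this narrow spread holds for an unsubstituted phenyl, a longer chain such as hexanoyl, or an ester carrying an amine or a carboxylic acid on the same carbonyl carbon. From the compounds shown here alone, all four values also come from a single cell line, so it remains unknown whether the same picture holds in other cells.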